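Cyclobutyl in Place of an Alkene on the Side Chain

The compounds below may be only part of what the source reports. "The series", "measured", "known", "first", "only" and "open" are said of these compounds alone.

Measured so far:
compound 1, `COc1cc(Cc2nc3c(N)nc(F)nc3n2CCOC(C)C)cc(OC)c1OC`, 15800 nM
compound 2, `CC/C=C\Cn1c(Cc2cc(OC)c(OC)c(OC)c2)nc2c(N)ncnc21`, 64600 nM

Of the compounds shown here, two have been measured in a functional assay on MCF7 cells (Homo sapiens) for antiproliferative activity; a lower number here means a stronger inhibitor, a higher number a weaker inhibitor. Compound 1 `COc1cc(Cc2nc3c(N)nc(F)nc3n2CCOC(C)C)cc(OC)c1OC` gives 15800 nM. Compound 2 `CC/C=C\Cn1c(Cc2cc(OC)c(OC)c(OC)c2)nc2c(N)ncnc21` gives 64600 nM, the higher of the two numbers; its nearest neighbour is compound 1, whose number lies lower by a margin beyond the scatter. For the measured compounds named here, the two differ in more than one place, so no single step can be read between them; their values show only that compound 2 is the weaker of the pair.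

Compound 3 `COc1cc(Cc2nc3c(N)ncnc3n2CC2CCC2)cc(OC)c1OC` has not yet been measured in this assay. It is related to compound 2 by the change (cyclobutyl in place of but-1-en-1-yl on a saturated chain carbon bound to an aromatic nitrogen). Nothing measured yet speaks to this change, since compound 1 differs from compound 2 elsewhere as well. Compound 3 is therefore expected to sit near 30000 nM, within a range from 8000 nM to 100000 nM. The expected step is a 2.2-fold lower number from compound 2 to compound 3 (0.33 log units; beyond the scatter), a modest move toward stronger inhibition that could still fall within the scatter.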

Compound 3, half-maximal inhibitory concentration: 45700 nM
Beside the measured number, compound 3's estimate is 1.5-fold (0.18 log units) below it; the measured number falls inside the stated range.
By their numbers in this assay, from the lowest: compound 1; then compounds 3 and 2 (each within the scatter of the next).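

In this assay, for the compounds shown here, placing cyclobutyl where but-1-en-1-yl stood, on a saturated chain carbon bound to an aromatic nitrogen, gives a 1.4-fold lower number from compound 2 to compound 3 (0.15 log units; within the scatter), the first reading of a single change at this position. An open chain carrying a double bond and a four-membered ring of carbon, built from the same atoms, therefore cannot be told apart here, so neither the double bond nor the ring shows any separate effect in this pair. The result comes with no accompanying measurement that could explain it, and this pair alone gives no account of why the two groups read alike.

Going by these compounds alone, compound 1 differs from both compound 2 and compound 3 in more than one place, so no step to it can be read, and how its side chain and its other difference each bear on its number remains open. Also open, on these data alone, is whether a longer chain, an amine or a carboxylic acid on this same chain carbon would move the number beyond the scatter, as this one change does not.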